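Rearranging hydroxyphenyl groups around a shared pyridine-free core? No: a shared core

The source may report more compounds than this note shows. Statements on the series, on what has been measured and on what is new or still open speak of the compounds shown alone.

Measured compounds and their values:
Compound 1 `Oc1ccc(-c2cc(-c3ccccc3O)cc(-c3cccc(O)c3)n2)cc1`: 4850 nM
Compound 2 `Oc1ccc(-c2cc(-c3cccc(O)c3)nc(-c3cccc(O)c3)c2)cc1`: 3810 nM
Compound 3 `Oc1cccc(-c2cc(-c3ccccc3O)nc(-c3ccccc3O)c2)c1`: 5020 nM

All three were tested in a functional assay on HCT-15 cells (Homo sapiens) for cytotoxicity, read by CCK-8 assay, with a stated time of 4 days; on this read-out higher numbers stand for weaker inhibition and lower numbers for stronger inhibition. Compound 2 carries the smallest of the three figures, yet compound 1 and compound 3 both sit within the usual scatter of it, so the three cannot be told apart. Compound 4 `Oc1cccc(-c2cc(-c3ccccc3O)cc(-c3cccc(O)c3)n2)c1` has the same atoms as compound 2, joined differently: 2-hydroxyphenyl in place of 4-hydroxyphenyl on an aromatic carbon. Since every measured rearrangement of these hydroxyphenyl groups has given much the same result, no step beyond the scatter is expected in this assay in either direction. The step from compound 2 to compound 4 is estimated at a 1.1-fold higher number from compound 2 to compound 4 (0.05 log units; within the scatter). Compound 4 is expected to give about 4300 nM, most likely between 2500 nM and 7500 nM.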

Compound 4, half-maximal inhibitory concentration: 5150 nM
For compound 4 the middle estimate is 1.2-fold (0.08 log units) below the measured one; the measured number falls inside the stated range.
By their numbers in this assay, from the lowest: compounds 2, 1, 3 and 4 (each within the scatter of the next).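

For the compounds shown here, these are the first single-place comparisons in this set. In this assay, placing 2-hydroxyphenyl instead of 4-hydroxyphenyl opposite the ring nitrogen gives a 1.4-fold higher number from compound 2 to compound 4 (0.13 log units; within the scatter), and the other single-place exchange of hydroxyphenyl groups gives a 1.1-fold higher number from compound 1 to compound 4 (0.03 log units; within the scatter), so neither change separates the compounds. No measurement here offers an explanation for this result.

Still open, from the compounds shown here alone, is whether a different group at the position opposite the ring nitrogen, such as an amine, a carboxylic acid or a methoxy group, would move the number beyond the scatter.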